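The compounds below may be only part of what the source reports. "The series", "measured", "known", "first", "only" and "open" are said of these compounds alone.

Measured compounds in the series:

- compound 1, `Clc1ccc(-c2cc(-c3ccccc3)n[nH]2)cc1`; in an assay on mitochondria from brain for inhibition of Amine oxidase [flavin-containing] B (Bos taurus), read by fluorescence (on this read-out higher numbers stand for weaker inhibition and lower numbers for stronger inhibition), compound 1 gives 6.03 nM
- compound 2, `Clc1ccc(-c2cc(-c3ccc(Cl)cc3)[nH]n2)cc1`; in this assay compound 2 gives 6030 nM
- compound 3, `Cc1ccc(-c2cc(-c3ccccc3)[nH]n2)cc1`; in this assay compound 3 gives 1 nM

Compound 3 stands at the lowest number of the three; compound 1 sits nearest to it and compound 2 furthest, both gaps beyond the scatter.

The step under consideration goes from compound 3 to compound 4, `Cc1ccc(-c2cc(-c3ccc(F)cc3)[nH]n2)cc1`. The change is fluoro in place of hydrogen on an aromatic carbon.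

Going by the values given here, one measured step bears on it: the move from compound 1 to compound 2, also a halogen entering on an aromatic carbon of the phenyl ring that carries no other group, gave a 1000-fold higher number from compound 1 to compound 2 (3.00 log units; beyond the scatter). Fluoro rather than chloro is the group entering here, and the ring that already carries a group differs between the pairs, so the measured step is only a rough guide. A weaker result than compound 3 is nevertheless expected, and the step of a 20-fold higher number from compound 3 to compound 4 (1.30 log units; beyond the scatter) is taken as the estimate, smaller than the chloro step but still beyond the scatter. Compound 4 is therefore expected at about 20 nM, within the range 2 nM to 300 nM, pending measurement in this assay.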

Compound 4, half-maximal inhibitory concentration: 100 nM
Beside the measured number, compound 4's estimate is 5.0-fold (0.70 log units) below it; the measured number falls inside the stated range.
By their numbers in this assay, from the lowest: compound 3; then compound 1; then compound 4; then compound 2.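

Fluoro in place of hydrogen, on an aromatic carbon para to a large group, is not tolerated in this assay: a 100-fold higher number from compound 3 to compound 4 (2.00 log units; beyond the scatter). Going by these compounds alone, until now, the only evidence of a loss at this position came from chloro, with chloro also on the other ring, as in a 1000-fold higher number from compound 1 to compound 2 (3.00 log units; beyond the scatter). The new step shows that a single fluorine atom is enough for a large loss and that the loss also occurs when the other ring carries methyl, although no measurement here accounts for this sensitivity.

The chloro step is the larger of the two on the printed values, but the pairs differ in both the entering halogen and the group on the other ring, so the share of each remains unresolved. Also open, as far as these compounds go, is whether the loss extends beyond halogens to a group such as methoxy, an amine or a carboxylic acid at this position, or whether any of these would keep the number close to that of the unsubstituted ring.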